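Aryl substituent swap on a sulfonylcarbamate series

The source may report more compounds than this note shows. Statements on the series, on what has been measured and on what is new or still open speak of the compounds shown alone.

Measured so far:
compound 1 `CCCCOC(=O)NS(=O)(=O)c1ccc(CCCC)cc1-c1ccc(Cn2ccnc2)cc1`, 5 nM
compound 2 `CCCCc1ccc(S(=O)(=O)NC(=O)OCC)c(-c2ccc(Cn3ccnc3)cc2)c1`, 2 nM

In an assay on membranes from uterus (Sus scrofa) for displacement of a labelled ligand from Type-2 angiotensin II receptor (Homo sapiens) (a higher number here means a weaker inhibitor, a lower number a stronger inhibitor), compound 1 gives 5 nM, the highest of the two numbers. Among the measured compounds shown here, compound 2 gives 2 nM, and the only measured step is a 2.5-fold lower number from compound 1 to compound 2 (0.40 log units; beyond the scatter). Compound 3 `CCCCOC(=O)NS(=O)(=O)c1ccc(OC(C)C)cc1-c1ccc(Cn2ccnc2)cc1` differs from compound 1 by isopropoxy in place of butyl on an aromatic carbon, a change on the aromatic ring, whereas the step from compound 1 to compound 2 concerns the carbamate chain only. For the measured compounds named here, no measured step bears on this change, so the expected step of no change at the digits printed from compound 1 to compound 3 (within the scatter) is none beyond the scatter, with an accordingly broad range. Compound 3 is therefore estimated at 5 nM, range 1.5 nM to 17 nM.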

Compound 3, inhibition constant: 15 nM
Compound 3: middle estimate off by 3.0-fold (0.48 log units), on the low side; the measured number falls inside the stated range.
By their numbers in this assay, from the lowest: compound 2; then compound 1; then compound 3.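

In this assay isopropoxy in place of butyl gives a 3.0-fold higher number from compound 1 to compound 3 (0.48 log units; beyond the scatter). The aromatic position para to the (butoxycarbonyl)sulfamoyl group therefore responds to this swap, even though both groups have 4 heavy atoms, and the earlier step covered only the carbamate chain. Nothing available explains this step.

The swap changes branching and adds an oxygen at once, so a butoxy or isobutyl group here would be needed to separate the two. Going by these compounds, whether the step carries over to the ethyl carbamate of compound 2 remains open.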